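Cyclic amide series: aryl in place of cyclopentyl

The source may hold more compounds than are shown below. What is called first, only, known or untested is meant among the compounds shown, and "the series" means these compounds.

Measured compounds in an in vitro functional assay on HEK293-A cells for positive allosteric modulation of metabotropic glutamate receptor 5 (Homo sapiens), read by fluorescence and calcium flux, with a stated time of 140 s; on this read-out lower numbers stand for an effect already at smaller amounts and higher numbers for an effect only at larger amounts of compound:

compound 1, `O=C(C1CCC1)N1CCCC[C@@H]1c1nc(-c2cccc(F)c2)no1`: 600 nM; 650 nM (2 entries)
compound 2, `O=C(C1CCCC1)N1CCCC1c1nc(-c2cccc(F)c2)no1`: 1000 nM

Compound 2 stands as the only number shown for it in this assay; a further entry for compound 2 gives no single number. Compound 1 has several entries, (the several entries of compound 1 in this assay, 600 nM; 650 nM (2 entries)), which lie close together. Among the compounds with values here, no pair of measured compounds differs in one place, so no measured step is available.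

Compound 3, `O=C(c1cccc(F)c1)N1CCCC1c1nc(-c2cccc(F)c2)no1`, is not yet measured. It differs from compound 2 by 3-fluorophenyl in place of cyclopentyl on a carbonyl carbon. With no measured step of this kind in the series, a change beyond the scatter is not assumed in either direction. The expected step from compound 2 to compound 3 in this assay is a 1.3-fold lower number from compound 2 to compound 3 (0.10 log units; within the scatter). For compound 3 the estimated value in this assay is 800 nM, expected to fall between 250 nM and 2500 nM.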

Compound 3, half-maximal effective concentration: 2600 nM
For compound 3 the middle estimate is 3.3-fold (0.51 log units) below the measured one, and the stated range ends below it.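

In this assay, the group on the carbonyl carbon bearing the amide-type nitrogen in a ring does affect the read-out: 3-fluorophenyl in place of cyclopentyl brings a 2.6-fold higher number from compound 2 to compound 3 (0.41 log units; beyond the scatter). Within the data shown here, this is the only measured step, and it runs against the aromatic group, although neither group has hydrogen-bond donors or acceptors or a net charge. Nothing measured here accounts for the size or direction of this step.

On these data alone, it remains open whether the shift belongs to the aromatic ring or to the fluorine, which unsubstituted phenyl on the same carbonyl carbon would separate, and whether isopropyl or pyridyl would read closer to cyclopentyl or to 3-fluorophenyl. Also open, as far as these compounds go, is whether the same change would give a similar step on the core of compound 1.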